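Chloro Substitution on the Fused Core of Compound 2

A few compounds are considered here, and "the series" means these few. Any claim that something is new, unique, unknown or untested is made for them only; others in the source may bear on it.

Compounds measured so far:
compound 1 `Clc1cccc2c1C=C(CC1CN=CN1)CC2` — 50.1 nM
compound 2 `NC1=NCC(CC2=Cc3ccccc3CC2)O1` — 1000 nM

In a functional assay for binding affinity to Norepinephrine transporter (Rattus norvegicus), read by radioligand binding, in the presence of a further agent that is not named here (a higher number here means a weaker inhibitor, a lower number a stronger inhibitor), compound 1 gives 50.1 nM. Compound 2 gives 1000 nM in this assay, the highest of the two numbers; the nearest is compound 1, and the gap between the two lies beyond the scatter. Among the measured compounds shown here, compound 1 and compound 2 differ from each other in more than one place, so no single step between the two measured compounds is defined, and the gap cannot be assigned to any one change.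

Compound 3 `NC1=NCC(CC2=Cc3c(Cl)cccc3CC2)O1` differs from compound 2 in one place, chloro in place of hydrogen on an aromatic carbon. For the measured compounds named here, no measured pair shows this change on its own. Compound 1 does carry a chloro on its fused ring and sits at the lower number, but it differs from compound 2 elsewhere as well, so that comparison is only suggestive. The step from compound 2 to compound 3 is expected to lower the number in this assay beyond the scatter, estimated as a 3.3-fold lower number from compound 2 to compound 3 (0.52 log units; beyond the scatter). Compound 3 is estimated at 300 nM, in the range 80 nM to 1200 nM.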

Compound 3, inhibition constant: < 1000 nM
Compound 3: a limit, no number; the forecaster's own chance of this, stated with the estimate: 5%; the middle value lies beyond the limit too.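

In this assay compound 3 gives < 1000 nM, which is a limit of the assay and not a number. Among the compounds shown here, this is the first pair that isolates chloro in place of hydrogen on an aromatic carbon, here ortho to a fused ring and meta to a fused ring, and it reads as a number no higher from compound 2 to compound 3 (the limit leaves the size open). The size of that step cannot be read, and neither can the step between compound 1 and compound 3, so the only firm information is where the limit sits: the limit of < 1000 nM in this assay, at which 1 of the 3 values shown sits.

The compounds shown leave open how far the number falls with chloro at this place, and whether it comes near compound 1 at 50.1 nM. Also open, on these data alone, is what bromo or methoxy in place of the chloro on the same aromatic carbon would give in this assay.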